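From 4-bromo-2-hydroxyphenyl to 5-bromo-2-hydroxyphenyl

The source may hold more compounds than are shown below. What is called first, only, known or untested is meant among the compounds shown, and "the series" means these compounds.

In a functional assay on Jurkat cells (Homo sapiens) for cytotoxicity, read by luminescence and CellTiter-Glo, with a stated time of 3 days (on this read-out lower numbers stand for stronger inhibition and higher numbers for weaker inhibition), compound 1 `O=C(Nc1cc(C(F)(F)F)cc(C(F)(F)F)c1)c1ccc(Br)cc1O` gives 930 nM, compound 2 `O=C(Nc1cc(C(F)(F)F)cc(C(F)(F)F)c1)c1ccc(-c2ccccc2)cc1O` gives 1240 nM and compound 3 `O=C(Nc1cccc(OC(F)(F)F)c1)c1cc(F)ccc1O` gives 700 nM. Compound 1 therefore stands within the usual scatter of both others. Compound 4 `O=C(Nc1cc(C(F)(F)F)cc(C(F)(F)F)c1)c1cc(Br)ccc1O` has the same atoms as compound 1, joined differently, with 5-bromo-2-hydroxyphenyl in place of 4-bromo-2-hydroxyphenyl on a carbonyl carbon. Among the compounds with values here, the only measured step touching this group is a 1.3-fold higher number from compound 1 to compound 2 (0.12 log units; within the scatter), where phenyl replaces bromo and the change stays within the scatter. It does not test moving the bromo group, so it offers only weak guidance. The expected step is a 1.2-fold lower number from compound 1 to compound 4 (0.07 log units; within the scatter), which is no change beyond the scatter. The expected value for compound 4 is 800 nM, with an estimated range from 400 nM to 1600 nM.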

Compound 4, half-maximal inhibitory concentration: 350 nM
Beside the measured number, compound 4's estimate is 2.3-fold (0.36 log units) above it, and the stated range ends above it.
By their numbers in this assay, from the lowest: compounds 4, 3, 1 and 2 (each within the scatter of the next, the first and the last beyond it).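

Moving the bromo group, with no atom gained or lost, gives a 2.7-fold lower number from compound 1 to compound 4 (0.42 log units; beyond the scatter) in this assay. This shows that where the bromo group sits on this ring can shift the number beyond the scatter, which replacing bromo with phenyl in the earlier step did not do. Nothing available explains the shift.

On these data alone, whether a phenyl group, an amine or a carboxylic acid would give a similar number in the place the bromo group takes in compound 4 remains open.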